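A smaller group replaces the 1,3-thiazol-2-yl ring

The source may hold more compounds than are shown below. What is called first, only, known or untested is meant among the compounds shown, and "the series" means these compounds.

Of the compounds shown here, three sharing one core have been tested in a functional assay on KB cells (Homo sapiens) for cytotoxicity, read by MTT assay, with a stated time of 3 days; a lower number here means a stronger inhibitor, a higher number a weaker inhibitor. Compound 1 `N#Cc1c(NN)nc(SCc2nc3ccccc3[nH]2)nc1-c1ccccc1` gives 2.55 nM, and compound 2 `CNc1nc(SCc2nc3ccccc3[nH]2)nc(-c2ccccc2)c1C#N` gives 2.7 nM. The gap between them, a 1.1-fold higher number from compound 1 to compound 2 (0.02 log units; within the scatter), lies within the usual scatter. Compound 3 `N#Cc1c(Nc2nccs2)nc(SCc2nc3ccccc3[nH]2)nc1-c1ccccc1` gives 14.7 nM, the highest number of the three, which makes it the weakest inhibitor in this small set.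

The next candidate, compound 4 `N#Cc1c(NC(N)=S)nc(SCc2nc3ccccc3[nH]2)nc1-c1ccccc1`, differs from compound 3 at a single place, on a nitrogen on an aromatic ring: a group of 3 heavy atoms (1 carbon, 1 nitrogen, 1 sulfur; no ring) in place of a group of 5 heavy atoms (3 carbon, 1 nitrogen, 1 sulfur; one five-membered aromatic ring with 2 hetero atoms), on a nitrogen on an aromatic ring.

Going by the values given here, two measured steps bear on this change. Putting the 1,3-thiazol-2-yl group in place of amino gave a 5.8-fold higher number from compound 1 to compound 3 (0.76 log units; beyond the scatter), and putting it in place of methyl gave a 5.4-fold higher number from compound 2 to compound 3 (0.74 log units; beyond the scatter). Both steps are modest and beyond the scatter. Amino and methyl have no ring, and neither does the entering group, so removing the ring is expected to lower the number. Among the compounds with values here, no tested compound carries the entering group, however, so the size of the drop is uncertain and it may not be as large as those two steps.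

The estimated step is a 2.9-fold lower number from compound 3 to compound 4 (0.47 log units; beyond the scatter). In this assay, compound 4 is expected to give about 5 nM, with a likely range from 2 nM to 15 nM.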

Compound 4, half-maximal inhibitory concentration: 3.2 nM
Compound 4: the middle estimate sits 1.6-fold (0.19 log units) above what was measured; the range from low to high includes it.
By their numbers in this assay, from the lowest: compounds 1, 2 and 4 (each within the scatter of the next); then compound 3.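

In this assay, taking away the 1,3-thiazol-2-yl ring and putting the ring-free group on the nitrogen brings the number down (a 4.6-fold lower number from compound 3 to compound 4 (0.66 log units; beyond the scatter)), a step that runs opposite to the rises seen when that ring entered in place of amino or methyl. The earlier compounds shown here carried only very small groups here, whereas compound 4 shows that a larger group without a ring can stand on this nitrogen and stay level with them (a 1.2-fold higher number from compound 2 to compound 4 (0.07 log units; within the scatter); a 1.3-fold higher number from compound 1 to compound 4 (0.10 log units; within the scatter)), both gaps lying within the scatter. Among these four compounds, size alone therefore does not order the numbers: only compound 3, the one with a ring on this nitrogen, stands apart, and no measurement at hand explains the difference.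

Still open, from the compounds shown here alone, is whether any ring on this nitrogen raises the number or only the 1,3-thiazol-2-yl ring does, a question that a phenyl or a pyridine ring in the same place would help to settle. Also open, going by these compounds, is how large a ring-free group can become before the number rises, which a longer chain such as butyl would test, and whether the sulfur of the entering group matters, which the matching urea, with oxygen in its place, would show.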